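From Isopropyl to Pentyl, Starting at a Limit

The source may hold more compounds than are shown below. What is called first, only, known or untested is meant among the compounds shown, and "the series" means these compounds.

In a functional assay on the whole organism with Rattus norvegicus as the target (on this read-out higher numbers stand for an effect only at larger amounts of compound and lower numbers for an effect already at smaller amounts), compound 2 `CC(C)c1ccc2nc(N)sc2c1` has no exact number and is recorded only as a limit, > 10 mg/kg. Going by the values given here, compound 1 `C[Si](C)(C)c1ccc2nc(N)sc2c1` is the only other measured compound, and compound 1 gives 5 mg/kg in this assay. Among the compounds with values here, the one measured step is an at least 2.0-fold higher number from compound 1 to compound 2 (0.30 log units; that floor lies within the scatter). On these data alone, its true size remains open, and the reading of it is bounded by the limit of > 10 mg/kg in this assay, at which 1 of the 2 values shown sits.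

Compound 3 `CCCCCc1ccc2nc(N)sc2c1` carries pentyl in place of isopropyl on an aromatic carbon, (pentyl in place of isopropyl on an aromatic carbon). Within the data shown here, the measured step also changes a group on an aromatic carbon, but neither of its groups is pentyl, and no measured pair shows what a longer chain does. It therefore gives no firm direction and no firm size for this change. With so little to go on, no clear step beyond the scatter is forecast, and another limit would be no surprise. The estimated step is a step that the limit leaves unreadable from compound 2 to compound 3. Compound 3 is expected at 12 mg/kg, with an estimated range from 5 mg/kg to 30 mg/kg.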

Compound 3, dose for half-maximal effect: 7.5 mg/kg
Estimate against measurement, compound 3: 1.6-fold (0.20 log units) above; measured number inside the range.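

In this assay the pentyl chain gives this position an exact number for a group made of carbon only, which isopropyl in compound 2 did not provide, and the change reads as an at least 1.3-fold lower number from compound 2 to compound 3 (0.12 log units; that floor lies within the scatter). On these data alone, the true size of that step stays open, and even its direction cannot be claimed beyond the scatter, because one end of it is not a number but a limit: the limit of > 10 mg/kg in this assay, at which 1 of the 3 values shown sits. The comparison with the silicon-bearing group of compound 1 reads as a 1.5-fold higher number from compound 1 to compound 3 (0.18 log units; within the scatter), so in this assay these two compounds cannot be told apart, and at this position a group of carbon only can stand in place of that group without a step beyond the scatter.

As far as these compounds go, how far the number of compound 2 lies from its limit remains unknown, and with it whether branching or chain length matters at this aromatic carbon at all. Also open, from the compounds shown here alone, is what a shorter chain such as ethyl, a longer chain such as heptyl, or a group of another kind such as an amine or a carboxylic acid would give in this same place.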